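This account rests on a few compounds, and the source may have more. Where it says the series, first, only, none or still open, it means among the compounds named here.

Going by the values given here, in an ADME assay on microsomes from liver (Mus musculus) for metabolic stability (on this read-out higher numbers stand for a longer-lived compound and lower numbers for a shorter-lived compound), compound 1 `CC(C)C(c1ccc(-c2ccc3cccc(F)c3c2)[nH]c1=O)N1CCCCS1(=O)=O` gives 0.0733 h, the only actual number so far. Compound 2 `CCn1ncc2c(F)cc(-c3ccc(C(CC)(CC)c4nncn4C)c(=O)[nH]3)cc21` is reported only as a limit of the assay, > 3 h. Among the compounds with values here, no step between measured compounds is available as a guide. Compound 3 `CC(C)C(c1ccc(-c2ccc3cccc(F)c3c2)[nH]c1=O)N1CCCCC1=O` departs from compound 1 in one place, with 2-oxopiperidin-1-yl entering on a saturated chain carbon bound to an aromatic carbon and a saturated chain carbon: a group of 7 heavy atoms (5 carbon, 1 nitrogen, 1 oxygen; one six-membered non-aromatic ring with 1 hetero atom) in place of a group of 8 heavy atoms (4 carbon, 1 nitrogen, 2 oxygen, 1 sulfur; one six-membered non-aromatic ring with 2 hetero atoms), on a saturated chain carbon bound to an aromatic carbon and a saturated chain carbon. The expected step, a 1.2-fold higher number from compound 1 to compound 3 (0.09 log units; within the scatter), stays within the usual scatter, with no firm direction. For compound 3 the estimated half-life is 0.09 h, with an expected range of 0.04 h to 0.25 h.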

Compound 3, half-life: 0.0967 h
For compound 3 the middle estimate is 1.1-fold (0.03 log units) below the measured one; measured number inside the range.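

In this assay, putting 2-oxopiperidin-1-yl in place of the sulfur-bearing ring on this saturated chain carbon gives a 1.3-fold higher number from compound 1 to compound 3 (0.12 log units; within the scatter). At this position, then, the two six-membered rings cannot be told apart on this read-out. No measured property shown bears on this step.

What the compounds leave open is whether an open-chain amine or a carboxylic acid on this same carbon would give a half-life beyond the scatter. They also leave open whether any change to the shared core would do so.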